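The source may report more compounds than this note shows. Statements on the series, on what has been measured and on what is new or still open speak of the compounds shown alone.

In an assay on HEK293 cells for agonist activity at prostaglandin E2 receptor EP2 subtype (Homo sapiens), read by a beta-galactosidase reporter and beta-arrestin recruitment, with a stated time of 90 min (on this read-out higher numbers stand for an effect only at larger amounts of compound and lower numbers for an effect already at smaller amounts), compound 2 `O=C(O)c1csc([C@H]2CC[C@@H]3[C@@H](COc4cccc(F)c4)[C@H](O)C[C@@H]3O2)n1` gives > 10000 nM, which is a limit of the assay rather than a measured number. Compound 1 `O=C(O)c1csc([C@H]2CC[C@@H]3[C@@H](CCCCCOc4ccccc4)[C@H](O)C[C@@H]3O2)n1`, which also carries a phenoxy group on its chain, gives > 10000 nM, again a limit. Compound 3 `O=C(O)c1csc([C@H]2CC[C@@H]3[C@@H](COc4cccc(OC(F)(F)F)c4)[C@H](O)C[C@@H]3O2)n1` gives 69 nM. For the measured compounds named here, the only measured step is an at least 140-fold lower number from compound 2 to compound 3 (2.16 log units; beyond the scatter), a change on the aromatic ring, and its true size is not fixed because the limit of > 10000 nM in this assay, at which 2 of the 3 values shown sit, hides where compound 2 really lies. Compound 4 `O=C(O)c1csc([C@H]2CC[C@@H]3[C@@H](CCCOc4ccccc4)[C@H](O)C[C@@H]3O2)n1` differs from compound 2 by 2-phenoxyethyl in place of 3-fluorophenoxy on a saturated chain carbon bound to a saturated ring carbon. Going by the values given here, this change moves the phenoxy group onto a longer chain and removes the fluorine, and no measured step addresses such a change. The two compounds with a plain phenoxy group, compound 1 and compound 2, both sit at the limit, so nothing points to a number as low as that of compound 3. Compound 4 is therefore expected to remain near the limit, with an estimate of 9000 nM and a range from 1500 nM to 40000 nM. The expected step is an at least 1.1-fold lower number from compound 2 to compound 4 (0.04 log units; that floor lies within the scatter).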

Compound 4, half-maximal effective concentration: > 10000 nM
Compound 4: a limit, no number (the forecaster's own chance of this, stated with the estimate: 60%); middle value at least 1.1-fold (0.04 log units) from the limit.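

Compound 4 is again a limit and not a number, so the steps linking it to compound 1 and compound 2 cannot be read, because all three compounds sit at the same limit: the limit of > 10000 nM in this assay, at which 3 of the 4 values shown sit. The compounds shown leave open how these three truly rank, and whether trifluoromethoxy would also lower the number on the longer chains.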